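Replacing Fluoro with Propyl: What Compound 3 May Show

A few compounds are considered here, and "the series" means these few. Any claim that something is new, unique, unknown or untested is made for them only; others in the source may bear on it.

For the measured compounds named here, in a functional assay on MGC-803 cells (Homo sapiens) for antiproliferative activity, read by CCK-8 assay, with a stated time of 72 h (a higher number here means a weaker inhibitor, a lower number a stronger inhibitor), compound 2 `Nc1ccccc1NC(=O)c1ccc(COc2ccc(F)cc2)cc1` gives 4970 nM, the only actual number so far. Compound 1 `Nc1ccccc1NC(=O)c1ccc(COc2ccc(Cl)cc2)cc1` reports only a limit, > 32000 nM. Going by the values given here, the single measured step is an at least 6.4-fold lower number from compound 1 to compound 2 (0.80 log units; beyond the scatter), with fluoro in place of chloro on an aromatic carbon, and its full size stays open, as the limit of > 32000 nM in this assay, at which 1 of the 2 values shown sits, shows. Compound 3 `CCCc1ccc(OCc2ccc(C(=O)Nc3ccccc3N)cc2)cc1` carries propyl in place of fluoro on that same aromatic carbon, para to a large group: propyl in place of fluoro on an aromatic carbon. This one step is thin evidence, but it is the only one that bears on the change. Given an at least 6.4-fold lower number from compound 1 to compound 2 (0.80 log units; beyond the scatter), fluoro is expected to remain the better of the groups tried here, so a moderate move towards weaker inhibition is expected. The estimated step is a 2.8-fold higher number from compound 2 to compound 3 (0.45 log units; beyond the scatter). For compound 3 the expected value is 14000 nM, within an estimated range of 4500 nM to 32000 nM.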

Compound 3, half-maximal inhibitory concentration: 4420 nM
The estimate for compound 3 lay 3.2-fold (0.50 log units) above the measured number; measured number below the stated range.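

In this assay, the exchange of fluoro for propyl on this aromatic carbon gives a 1.1-fold lower number from compound 2 to compound 3 (0.05 log units; within the scatter), so two very different groups, a single fluorine and a propyl chain, leave compound 2 and compound 3 level at this position. Propyl in place of chloro gives an at least 7.2-fold lower number from compound 1 to compound 3 (0.85 log units; beyond the scatter), so the departure from compound 1 now appears with two replacements rather than one, and among the three groups shown, chloro alone stands apart. The value of compound 1 is a limit, so the full size of both steps from it stays open: the limit of > 32000 nM in this assay, at which 1 of the 3 values shown sits.

As far as these compounds go, what an amine or a carboxylic acid on this carbon would do remains open, as does whether a chain longer than propyl would keep the level of compound 3. The three compounds also do not tell why chloro alone stands apart.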